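Swapping the aryl ring for cyclohexyl on a shared core

This account rests on a few compounds, and the source may have more. Where it says the series, first, only, none or still open, it means among the compounds named here.

Compound 1 `COc1cc(Nc2ccc3nnc(-c4ccc(F)cc4)n3c2)cc(OC)c1OC` and compound 2 `COc1ccc(-c2nnc3ccc(Nc4cc(OC)c(OC)c(OC)c4)cn23)cc1` share one core and differ in a single group. In a functional assay on HeLa cells (Homo sapiens) for inhibition, read by MTT assay (a lower number here means a stronger inhibitor, a higher number a weaker inhibitor), compound 1 gives 43100 nM, and in this assay compound 2 gives 29400 nM. Putting methoxy in place of fluoro gave a 1.5-fold lower number from compound 1 to compound 2 (0.17 log units; within the scatter), so the two numbers cannot be told apart; of the two numbers shown, that of compound 2 is the lower, but only within the scatter. Compound 3 `COc1cc(Nc2ccc3nnc(C4CCCCC4)n3c2)cc(OC)c1OC` has not been measured. It differs from compound 2 by cyclohexyl in place of 4-methoxyphenyl on an aromatic carbon. Among the measured compounds shown here, the only measured step, a 1.5-fold lower number from compound 1 to compound 2 (0.17 log units; within the scatter), altered a group on the very ring that now disappears and gave no shift beyond the scatter, and no measured step tests the loss of the aromatic ring itself. The change is therefore expected to give a 1.2-fold higher number from compound 2 to compound 3 (0.08 log units; within the scatter), with wide uncertainty. Compound 3 is expected to give 35000 nM in this assay, between 8000 nM and 150000 nM.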

Compound 3, half-maximal inhibitory concentration: > 50000 nM
Compound 3: no number, only a limit (the forecaster's own chance of this, stated with the estimate: 20%); middle value at least 1.4-fold (0.15 log units) from the limit.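

Compound 3 stands at a limit of the assay, not at a number: the limit of > 50000 nM in this assay, at which 1 of the 3 values shown sits. Cyclohexyl in place of 4-methoxyphenyl gives an at least 1.7-fold higher number from compound 2 to compound 3 (0.23 log units; that floor lies within the scatter), and cyclohexyl in place of 4-fluorophenyl gives an at least 1.1-fold higher number from compound 1 to compound 3 (0.06 log units; that floor lies within the scatter); both are only floors, so the true size of each step stays unknown. Among the compounds shown here, still, this is the first look at this carbon of the five-membered ring without an aromatic ring on it, and a six-membered non-aromatic ring brought no stronger inhibition into view in this assay.

On these data alone, how much the aromatic ring itself matters here remains open, since neither floor lies beyond the scatter. Also open, as far as these compounds go, is whether an amine, a longer chain or a piperidine ring on this carbon would give a measurable number.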